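Amide nitrogen substituent swap in a cinnamate ester series

The source may hold more compounds than are shown below. What is called first, only, known or untested is meant among the compounds shown, and "the series" means these compounds.

Going by the values given here, compound 1 `COCOc1cc(/C=C/C(=O)OCC(=O)NCc2ccco2)ccc1OCc1ccccc1` is the one member of the set with a numerical result: in a functional assay on K562 cells (Homo sapiens) for cytotoxicity, read by MTT assay, with a stated time of 72 h (a lower number here means a stronger inhibitor, a higher number a weaker inhibitor), compound 1 gives 300 nM. The other two measured members reach only limits of the assay. Compound 2 `CCOc1ccc(COc2c(OC)cc(/C=C/C(=O)OCC(=O)Nc3ccccc3)cc2OC)cc1` gives > 200000 nM in this assay, a limit and not a number. Compound 3 `COc1ccc(NC(=O)COC(=O)/C=C/c2cc(OC)c(OCc3ccc(Cl)c(Cl)c3)c(OC)c2)cc1` gives > 200000 nM in this assay, again a limit rather than a number. Compound 1 therefore stands alone with a measured concentration, set against the limit of > 200000 nM in this assay, at which 2 of the 3 values shown sit, for the other two. Among the compounds with values here, compounds 2 and 3 each differ from compound 1 in more than one place, so no single step between measured compounds is available within the set.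

Compound 4 `COCOc1cc(/C=C/C(=O)OCC(=O)NN2CCOCC2)ccc1OCc1ccccc1` has not yet been measured in this assay. It differs from compound 1 in one place: morpholin-4-yl in place of (furan-2-yl)methyl on an amide-type nitrogen. The rest of the core of compound 1 is kept unchanged. Within the data shown here, no measured pair isolates this change, so the expectation rests on compound 1 alone, which gives 300 nM. The step from compound 1 to compound 4 is expected to be a modest loss, a 2.3-fold higher number from compound 1 to compound 4 (0.37 log units; beyond the scatter), of a size near the edge of the usual scatter. Compound 4 is estimated at 700 nM in this assay, with a range from 150 nM to 4000 nM.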

Compound 4, half-maximal inhibitory concentration: 32400 nM
Compound 4: the middle estimate sits 46-fold (1.67 log units) below what was measured, outside the stated range (above it).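

Going by these compounds alone, the first single-place step falls on the amide-type nitrogen, and it is large: in this assay, the change gives a 110-fold higher number from compound 1 to compound 4 (2.03 log units; beyond the scatter). This position therefore does not tolerate every group of this size, since (furan-2-yl)methyl and morpholin-4-yl have the same count of heavy atoms, and neither brings a hydrogen-bond donor or a net charge; they differ in ring type and in hydrogen-bond acceptors. Nothing measured here bears on why the change costs this much.

Compounds 2 and 3 remain at a limit of the assay and not a number, so they give no size for any change at this nitrogen: the limit of > 200000 nM in this assay, at which 2 of the 4 values shown sit. Still open, going by these compounds, is which part of the change carries the loss, the furan ring, the methyl link that (furan-2-yl)methyl holds and morpholin-4-yl lacks, or the morpholine ring itself; a benzyl group, a tetrahydrofuran-2-ylmethyl group or a 2-(morpholin-4-yl)ethyl chain on the same nitrogen, with the rest of the core of compound 1 kept, would separate these.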